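Amine variation at the thiocarbonyl carbon

The compounds below may be only part of what the source reports. "The series", "measured", "known", "first", "only" and "open" are said of these compounds alone.

Compound 2 `CC(C)N(C(=S)SCc1coc2ccccc2c1=O)C(C)C` carries a diisopropylamino group on a thiocarbonyl carbon. In a functional assay on HeLa cells (Homo sapiens) for antiproliferative activity, read by MTT assay, with a stated time of 72 h (a lower number here means a stronger inhibitor, a higher number a weaker inhibitor), compound 2 gives > 30000 nM, which is a limit of the assay and not a number. Compound 1 `O=c1c(CSC(=S)N2CCCC2)coc2ccccc12` carries pyrrolidin-1-yl in the same place. In this assay compound 1 gives > 25000 nM, again a limit rather than a number. For the measured compounds named here, the one measured step, a step that the two limits leave unreadable from compound 1 to compound 2, is unreadable; the limit of > 25000 nM in this assay, at which 1 of the 2 values shown sits, and the limit of > 30000 nM in this assay, at which 1 of the 2 values shown sits, mark its two ends. Compound 3 `O=c1c(CSC(=S)N2CCCCC2)coc2ccccc12` differs from compound 2 in that (piperidin-1-yl in place of diisopropylamino on a thiocarbonyl carbon). Going by the values given here, no measured step tells how a piperidin-1-yl ring changes the read-out; the only comparison in hand, a step that the two limits leave unreadable from compound 1 to compound 2, shows that exchanging one such amine for another left both compounds at limits. Compound 3 is therefore expected to remain in the same region, with the step that the limit leaves unreadable from compound 2 to compound 3 expected to lie within the scatter and the result most likely a limit once more. The estimate for compound 3 in this assay is 40000 nM, with a range from 15000 nM to 100000 nM.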

Compound 3, half-maximal inhibitory concentration: 2300 nM
Estimate against measurement, compound 3: 17-fold (1.24 log units) above; measured number below the stated range.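

In this assay, the amine on a thiocarbonyl carbon proves able to move the read-out: piperidin-1-yl in place of diisopropylamino gives an at least 13-fold lower number from compound 2 to compound 3 (1.11 log units; beyond the scatter), and piperidin-1-yl in place of pyrrolidin-1-yl gives an at least 10-fold lower number from compound 1 to compound 3 (1.03 log units; beyond the scatter). Both steps lie beyond the scatter, so this position is not indifferent to the choice of amine, something the earlier pair, with neither compound giving a number, could not show. A ring on the nitrogen is not enough on its own: compound 1 also carries one, yet of the three compounds only compound 3, with its piperidin-1-yl ring, gives a number rather than a limit.

Going by these compounds, the results for compound 1 and compound 2 are limits of the assay and not numbers, so the full size of both new steps stays open, and the step between those two compounds cannot be read. Also open, on these data alone, is whether the lower number holds for another cyclic amine in the same place, such as morpholin-4-yl, 4-methylpiperazin-1-yl or azepan-1-yl.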